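Amide nitrogen substituent: from compound 2 to compound 4

The source may hold more compounds than are shown below. What is called first, only, known or untested is meant among the compounds shown, and "the series" means these compounds.

Measured so far:
Compound 1 `O=c1cc(-c2ccccc2)[nH]c(=O)n1O`: in an assay on isolated protein for inhibition of deoxyribonuclease-1 (Homo sapiens) (a higher number here means a weaker inhibitor, a lower number a stronger inhibitor), compound 1 gives > 100000 nM, a limit of the assay rather than a number.
Compound 2 `CCCNC(=O)c1nc(-c2cccs2)[nH]c(=O)c1O`: in this assay compound 2 gives > 100000 nM, again a limit.
Compound 3 `O=C(NCCO)c1nc(-c2cccs2)[nH]c(=O)c1O`: in this assay compound 3 gives > 100000 nM, also a limit.

Compound 2 therefore stands nowhere in particular: its value in this assay is a limit, and the same holds for every compound measured, as the line the limit of > 100000 nM in this assay, at which 3 of the 3 values shown sit, records. Among the compounds with values here, the single step between neighbours, a step that the two limits leave unreadable from compound 2 to compound 3, is unreadable for that reason.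

Compound 4 `O=C(Nc1cccnc1)c1nc(-c2cccs2)[nH]c(=O)c1O` differs from compound 2 by pyridin-3-yl in place of propyl on an amide-type nitrogen. No measured step touches a change on the amide nitrogen of this kind; the only step shown, from compound 2 to compound 3, concerns the chain and is itself unreadable. Within the data shown here, with no readable step to lean on, and every value so far a limit, the expectation for compound 4 in this assay is a value near the limit, estimated at 100000 nM with a range from 30000 nM to 300000 nM. Relative to compound 2 this estimate means a step of a number no higher from compound 2 to compound 4 (the limit leaves the size open), expected to be no change beyond the scatter, with a high chance that only a limit is reported.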

Compound 4, half-maximal inhibitory concentration: > 100000 nM
Compound 4 gave a limit, no number; the forecaster's own chance of this, stated with the estimate: 75%; the middle value lies on the limit itself.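

In this assay compound 4 gives > 100000 nM, a limit, so the steps reaching it from compound 2 and compound 3 cannot be read: the limit of > 100000 nM in this assay, at which 4 of the 4 values shown sit.

On these data alone, whether any substituent on the amide nitrogen gives a readable number in this assay stays open.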